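From Compound 2 to Compound 4 in Paw Edema Inhibition

This account rests on a few compounds, and the source may have more. Where it says the series, first, only, none or still open, it means among the compounds named here.

Three compounds have been measured in a functional assay on the whole organism (strain Wistar) for inhibition, with Rattus norvegicus as the target, read by paw edema, with stated times of 30 min and 0.5 h, at a dose of 20 mg/kg; on this read-out higher numbers stand for more inhibition at the one dose given (going by the name of the read-out) and lower numbers for less inhibition:
Compound 1, `CCOC(=O)C1=C(C)NC(C)=C(C(=O)OCC)C1c1ccc(OCC(=O)Nc2c(C)cccc2C)cc1`, gives 15.9%.
Compound 2, `CCOC(=O)C1=C(C)NC(C)=C(C(=O)OCC)C1c1ccc(OCC(=O)NNC(=O)c2ccc(C)cc2)cc1`, gives 16.7%.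
Compound 3, `CCOC(=O)C1=C(C)NC(C)=C(C(=O)OCC)C1c1ccc(OCC(=O)n2nc(C)cc2C)cc1`, gives 13.7%.

Compound 2 holds the highest of the three numbers, yet its separations from the others, a number 0.8 percentage points higher from compound 1 to compound 2 (within the scatter) and a number 3 percentage points lower from compound 2 to compound 3 (within the scatter), both lie within the scatter, so no ranking can be drawn. Compound 4, `CCOC(=O)C1=C(C)NC(C)=C(C(=O)OCC)C1c1ccc(OCC(=O)NN2C(=O)c3ccccc3C2=O)cc1`, is not yet measured. It differs from compound 2 in one place: a group of 11 heavy atoms (8 carbon, 1 nitrogen, 2 oxygen; one five-membered non-aromatic ring with 1 hetero atom, one six-membered aromatic ring of carbon only) in place of a group of 10 heavy atoms (8 carbon, 1 nitrogen, 1 oxygen; one six-membered aromatic ring of carbon only), on an amide-type nitrogen. All three known steps alter this same end of the chain, and each stays within the scatter, including a number 2.2 percentage points lower from compound 1 to compound 3 (within the scatter). The step to compound 4 is therefore expected to be a number 1.7 percentage points lower from compound 2 to compound 4 (within the scatter). Compound 4 is estimated at 15%, within 8% to 23%.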

Compound 4, a percentage reported as inhibition, in the whole organism at one dose (the size of the read-out at that dose, not a potency): 34.1%
The estimate for compound 4 lay 19.1 percentage points below the measured number, outside the stated range (above it).
By their numbers in this assay, from the lowest: compounds 3, 1 and 2 (each within the scatter of the next); then compound 4.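

Among the compounds shown here, the end of the chain can move this read-out after all in this assay: the steps are a number 17.4 percentage points higher from compound 2 to compound 4 (beyond the scatter) and a number 18.2 percentage points higher from compound 1 to compound 4 (beyond the scatter) and a number 20.4 percentage points higher from compound 3 to compound 4 (beyond the scatter), whereas the changes among the earlier compounds stayed within the scatter. On the amide-type nitrogen, the entering group has a five-membered non-aromatic ring and 0 hydrogen-bond donors, but this one compound cannot show which feature matters. No evidence here explains the rise.

As far as these compounds go, whether the six-membered aromatic ring is needed remains open. So does how a plain amine or a carboxylic acid would fare on this nitrogen.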